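The compounds below may be only part of what the source reports. "The series", "measured", "known", "first", "only" and "open" are said of these compounds alone.

In a functional assay on DU-145 cells (Homo sapiens) for inhibition, read by trypan blue exclusion, with a stated time of 96 h (on this read-out lower numbers stand for stronger inhibition of growth and higher numbers for weaker inhibition of growth), compound 1 `O=C(/C(=C\c1ccc(Cl)cc1Cl)S(=O)(=O)c1ccc(Br)cc1)c1ccc(Br)cc1` gives 10000 nM and compound 2 `O=C(/C(=C\c1ccc(F)cc1F)S(=O)(=O)c1ccc(Br)cc1)c1ccc(Br)cc1` gives 7500 nM. These two values lie within the usual scatter of each other, so compound 2 stands level with compound 1 and neither can be ranked above the other.

Compound 3 `O=C(/C(=C\c1ccc(F)cc1)S(=O)(=O)c1ccc(Br)cc1)c1ccc(Br)cc1` is compound 2 with one small edit: hydrogen in place of fluoro on an aromatic carbon. This puts hydrogen in place of fluoro on an aromatic carbon, turning 2,4-difluorophenyl into 4-fluorophenyl.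

Within the data shown here, only one measured step touches this ring: a 1.3-fold lower number from compound 1 to compound 2 (0.12 log units; within the scatter). It exchanged the halogens of a 2,4-dichlorophenyl group for those of a 2,4-difluorophenyl group, but it removed neither of them, so it is only an indirect guide. Among the measured compounds shown here, no measured step shows what losing a fluoro does here. For the measured compounds named here, with that small step from compound 2 as the only evidence, no change beyond the scatter is expected in this assay, in either direction. The expected change is a 1.1-fold lower number from compound 2 to compound 3 (0.03 log units; within the scatter). For compound 3 the estimated value is 7000 nM, with an expected range from 3000 nM to 15000 nM.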

Compound 3, concentration for 50% growth inhibition: 4000 nM
For compound 3 the middle estimate is 1.8-fold (0.24 log units) above the measured one, and the stated range covers the measured number.
By their numbers in this assay, from the lowest: compounds 3, 2 and 1 (each within the scatter of the next, the first and the last beyond it).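

Among these compounds, compound 3 gives the first direct look at this place on the ring, an aromatic carbon ortho to a large group, with the fluoro simply taken away rather than traded for another halogen. In this assay, the result is a 1.9-fold lower number from compound 2 to compound 3 (0.27 log units; within the scatter), so the fluoro at this place can be replaced by hydrogen without a change beyond the scatter. The wider comparison gives the first difference in this small set that exceeds the scatter, a 2.5-fold lower number from compound 1 to compound 3 (0.40 log units; beyond the scatter), but it replaces the whole 2,4-dichlorophenyl group with 4-fluorophenyl, so it cannot be assigned to one atom, and nothing measured here explains it.

The compounds shown leave open what a larger or different group at this same place would do, such as a methoxy group or an amine, since only hydrogen and fluoro can be compared there directly. They also leave open whether the remaining fluoro of the 4-fluorophenyl group matters, which a plain phenyl ring or one carrying a nitrile in its place could help to settle.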